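Bromo for amino: carrying one measured step across the series

A few compounds are considered here, and "the series" means these few. Any claim that something is new, unique, unknown or untested is made for them only; others in the source may bear on it.

In a functional assay on MCF7 cells (Homo sapiens) for cytotoxicity, read by MTT assay, with a stated time of 24 h (a higher number here means a weaker inhibitor, a lower number a stronger inhibitor), compound 1 `Nc1ccc2sc(NC(=S)NC(=O)c3ccc([N+](=O)[O-])cc3)nc2c1` gives 33200 nM. Compound 3 `Nc1ccc2sc(NC(=S)NC(=O)N3CCOCC3)nc2c1` gives 26400 nM in this assay; the difference between the core of compound 1 and the core of compound 3 is not broken down here, and the two values lie within the scatter of each other. Compound 2 `O=C(NC(=S)Nc1nc2cc(Br)ccc2s1)N1CCOCC1` gives 18100 nM in this assay. The change from compound 3 to compound 2 is bromo in place of amino on an aromatic carbon and the step it made was a 1.5-fold lower number from compound 3 to compound 2 (0.16 log units; within the scatter).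

Compound 4 `O=C(NC(=S)Nc1nc2cc(Br)ccc2s1)c1ccc([N+](=O)[O-])cc1` has not been measured. It differs from compound 1 by bromo in place of amino on an aromatic carbon, the same change at the same place as between compound 3 and compound 2. For compound 4 the expected step is a 1.5-fold lower number from compound 1 to compound 4 (0.18 log units; within the scatter), which rests on a 1.5-fold lower number from compound 3 to compound 2 (0.16 log units; within the scatter). Compound 4 is estimated at 22000 nM, expected between 9000 nM and 55000 nM.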

Compound 4, half-maximal inhibitory concentration: 32400 nM
Beside the measured number, compound 4's estimate is 1.5-fold (0.17 log units) below it, and the stated range covers the measured number.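

Bromo in place of amino on an aromatic carbon gives a 1.0-fold lower number from compound 1 to compound 4 (0.01 log units; within the scatter). In this assay, this step and the earlier one on the other core do not differ beyond the scatter: the same change on two cores in this assay, a 1.5-fold lower number (0.16 log units; within the scatter) from compound 3 to compound 2 and a 1.0-fold lower number (0.01 log units; within the scatter) from compound 1 to compound 4, 1.4-fold (0.15 log units) apart, within the scatter of two such steps

So the change carries between these two cores without a detectable gap, but with both steps within the scatter, this is agreement between two small steps only; it does not show that bromo lowers the number on either core, nor how the change would read on a third core.

Open, going by these compounds, is how a chloro, a methoxy or a carboxylic acid would read at this place on the aromatic ring. Also open, on these data alone, is whether any group there moves the number beyond the scatter.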